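Three amides on one shared core: a small change

The source may hold more compounds than are shown below. What is called first, only, known or untested is meant among the compounds shown, and "the series" means these compounds.

Measured so far:
- Compound 1, `COC(=O)C1=C(C)NC(=O)NC1c1cccs1`, gives 6% in an assay on membranes from CHO cells for displacement of a labelled ligand from adenosine receptor A1 (Homo sapiens), read by scintillation counting, with a stated time of 60 min, tested at 1 uM; a lower number here means less inhibition, a higher number more inhibition at the concentration tested (going by the name of the read-out).
- Compound 2, `CC1=C(C(=O)NC(C)C)C(c2cccs2)NC(=O)N1`, gives 2% in this assay.

Compound 2 stands at the lowest of the two numbers, but its nearest neighbour, compound 1, lies within the scatter of it, so the two cannot be told apart. Among the compounds with values here, the one measured step, a number 4 percentage points lower from compound 1 to compound 2 (within the scatter), swapped the group on the carbonyl carbon and moved the number only within the scatter.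

Compound 3, `CCN(CC)C(=O)C1=C(C)NC(=O)NC1c1cccs1`, is not yet measured. It differs from compound 2 by diethylamino in place of isopropylamino on a carbonyl carbon. This is again a swap of the group on the carbonyl carbon, the same kind of change as the measured step, which stayed within the scatter. The step from compound 2 to compound 3 in this assay is therefore expected to be a number 2 percentage points higher from compound 2 to compound 3 (within the scatter), that is, no change beyond the scatter. For compound 3 the estimated value is 4%, expected to fall between -6% and 14%.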

Compound 3, a percentage reported as inhibition, at one concentration (the size of the read-out at that concentration, not a potency): 13%
For compound 3 the middle estimate is 9 percentage points below the measured one; the measured number falls inside the stated range.
By their numbers in this assay, from the lowest: compounds 2, 1 and 3 (each within the scatter of the next, the first and the last beyond it).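

Within the data shown here, on the carbonyl carbon of the shared core, diethylamino in place of isopropylamino gives the first step beyond the scatter in this assay (a number 11 percentage points higher from compound 2 to compound 3 (beyond the scatter)), though only a modest one. Diethylamino in place of methoxy stays within the scatter (a number 7 percentage points higher from compound 1 to compound 3 (within the scatter)), so compound 1 cannot be told apart from either amide, and only the two amides separate at this position. No measurement shown here accounts for the gap between the two amides.

Going by these compounds, it remains open whether other groups on this carbonyl carbon, such as dimethylamino, the longer dipropylamino or a carboxylic acid, would take the number further in either direction. All three readings are also small effects at a single concentration, so they leave the potency of these compounds open.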